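Methoxy addition next in a brominated chalcone series

This account rests on a few compounds, and the source may have more. Where it says the series, first, only, none or still open, it means among the compounds named here.

- compound 1 `COc1cc(Br)cc(/C=C/C(=O)c2ccccc2)c1O`: in a functional assay on MCF7 cells (Homo sapiens) for antiproliferative activity, read by sulforhodamine B assay, with a stated time of 72 h, tested at 30 uM (on this read-out lower numbers stand for a stronger effect and higher numbers for a weaker effect at the one concentration tested), compound 1 gives 28.1%
- compound 2 `COc1cc(Cl)cc(/C=C/C(=O)c2ccc(Br)cc2)c1O`: in this assay compound 2 gives 26.3%
- compound 3 `O=C(/C=C/c1cc(Br)ccc1O)c1ccc(Br)cc1`: in this assay compound 3 gives 28.3%

The three measured numbers sit close together. Compound 3 is not set apart from compound 1 or from compound 2: both gaps lie within the usual scatter of repeated measurements, so no order among the three can be read from these numbers. Going by the values given here, no pair of the measured compounds differs in only one place, so no single-change step is available.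

Compound 4 `COc1cc(Br)cc(/C=C/C(=O)c2ccc(Br)cc2)c1O` is the next compound to be measured. It differs from compound 3 by methoxy in place of hydrogen on an aromatic carbon. Compound 1 and compound 2 both carry a methoxy group and return numbers in the same band as compound 3, so nothing in the present numbers points to a step beyond the scatter for the change from compound 3 to compound 4 in this assay.

The step of a number 1.3 percentage points lower from compound 3 to compound 4 (within the scatter) is expected to stay within the scatter. Compound 4 is estimated at 27%, with a range from 17% to 37%.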

Compound 4, a percentage reported as activity, at one concentration (the size of the read-out at that concentration, not a potency): 48.3%
Compound 4: middle estimate off by 21.3 percentage points, on the low side; the whole stated range lies below it.
By their numbers in this assay, from the lowest: compounds 2, 1 and 3 (each within the scatter of the next); then compound 4.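

In this assay methoxy in place of hydrogen on an aromatic carbon, ortho to a hydroxy group and meta to a bromo group, gives a number 20 percentage points higher from compound 3 to compound 4 (beyond the scatter) and thus a weaker effect at the one concentration tested. Methoxy does not bring this weakening wherever it stands on its own: compound 1 and compound 2 both carry it, yet bromo in place of chloro gives a number 22 percentage points higher from compound 2 to compound 4 (beyond the scatter) and bromo in place of hydrogen gives a number 20.2 percentage points higher from compound 1 to compound 4 (beyond the scatter) in the same read-out. Among these four compounds, the weaker effect appears only in compound 4, which combines methoxy with both bromo groups.

No measurement at hand bears on the reason for this weakening.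
As far as these compounds go, whether an ethoxy group or an amine on the same aromatic carbon would keep the weaker effect of compound 4 remains open.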